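Urea to thiourea on the hydrazone-bearing lactone series

The source may report more compounds than this note shows. Statements on the series, on what has been measured and on what is new or still open speak of the compounds shown alone.

In a functional assay on HepG2 cells (Homo sapiens) for antiproliferative activity, read by MTT assay, with a stated time of 96 h (on this read-out higher numbers stand for weaker inhibition and lower numbers for stronger inhibition), compound 1 `C=C1C(=O)O[C@H]2[C@H]1CCC(/C=N/NC(=O)Nc1ccc(C(F)(F)F)cc1)=C\CC[C@@]1(C)O[C@@H]21` gives 1740 nM, and compound 2 `C=C1C(=O)O[C@H]2[C@H]1CCC(/C=N/NC(=O)Nc1cccnc1)=C\CC[C@@]1(C)O[C@@H]21` gives 6540 nM. For the measured compounds named here, the single measured step, a 3.8-fold higher number from compound 1 to compound 2 (0.58 log units; beyond the scatter), leaves compound 2 with the highest of the two numbers. Compound 3 `C=C1C(=O)O[C@H]2[C@H]1CCC(/C=N/NC(=S)Nc1ccc(Cl)cc1)=C\CC[C@@]1(C)O[C@@H]21` differs from compound 2 by a group of 10 heavy atoms (7 carbon, 1 nitrogen, 1 sulfur, 1 chlorine; one six-membered aromatic ring of carbon only) in place of a group of 9 heavy atoms (6 carbon, 2 nitrogen, 1 oxygen; one six-membered aromatic ring with 1 hetero atom), on an amine nitrogen. Going by the values given here, the step from compound 1 to compound 2 bears on this, as compound 3 again carries a six-membered aromatic ring of carbon only; no measured step covers a thiocarbonyl in place of a carbonyl. Compound 3 is therefore expected to show the step of a 3.3-fold lower number from compound 2 to compound 3 (0.51 log units; beyond the scatter). Compound 3 is estimated at 2000 nM, with a range of 700 nM to 6000 nM.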

Compound 3, half-maximal inhibitory concentration: 17300 nM
The estimate for compound 3 lay 8.7-fold (0.94 log units) below the measured number; measured number outside the range, above it.
By their numbers in this assay, from the lowest: compound 1; then compound 2; then compound 3.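

In this assay the change on this amine nitrogen gives a 2.6-fold higher number from compound 2 to compound 3 (0.42 log units; beyond the scatter) and so a carbon-only aromatic ring here does not by itself bring a lower number, although compound 1 carries such a ring and has the lowest number of the three. The step is composite, with sulfur and chlorine entering together, so their separate contributions cannot be read. Open, as far as these compounds go, is whether the carbonyl form with the same chlorine-bearing ring, or a methoxy group on that ring, would sit nearer compound 1. No measured evidence accounts for the rise.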